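Replacing a Sulfur-Bearing Group with Diethylcarbamoyl

The compounds below may be only part of what the source reports. "The series", "measured", "known", "first", "only" and "open" are said of these compounds alone.

Among the measured compounds shown here, in a functional assay on A549 cells (Homo sapiens) for antiproliferative activity, read by MTT assay, with a stated time of 48 h (on this read-out lower numbers stand for stronger inhibition and higher numbers for weaker inhibition), compound 2 `CSC(=S)OC/C1=C/C[C@](C)(CCC=C(C)C)/C=C/[C@@H](OC(=O)C=C(C)C)[C@](C)(O)/C=C/C1=O` gives 380 nM, the lower of the two numbers so far, and compound 1 `CC(C)=CCC[C@]1(C)/C=C/[C@@H](OC(=O)C=C(C)C)[C@](C)(O)/C=C/C(=O)/C(CN=[N+]=[N-])=C\C1` gives 1720 nM. Compound 3 `CCN(CC)C(=O)/C1=C/C[C@](C)(CCC=C(C)C)/C=C/[C@@H](OC(=O)C=C(C)C)[C@](C)(O)/C=C/C1=O` differs from compound 2 on a double-bonded ring carbon: a group of 7 heavy atoms (5 carbon, 1 nitrogen, 1 oxygen; no ring) in place of a group of 6 heavy atoms (3 carbon, 1 oxygen, 2 sulfur; no ring), on a double-bonded ring carbon. For the measured compounds named here, the only measured step that bears on this is a 4.5-fold lower number from compound 1 to compound 2 (0.66 log units; beyond the scatter), a modest change made on the group at this same ring carbon. Starting from the lower number, that of compound 2 at 380 nM, a rise of similar size is expected, and the expected step is a 3.2-fold higher number from compound 2 to compound 3 (0.50 log units; beyond the scatter). The estimate for compound 3 is 1200 nM, with a range from 350 nM to 4500 nM.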

Compound 3, half-maximal inhibitory concentration: 11300 nM
Beside the measured number, compound 3's estimate is 9.4-fold (0.97 log units) below it, and the stated range ends below it.
By their numbers in this assay, from the lowest: compound 2; then compound 1; then compound 3.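

In this assay this double-bonded ring carbon proves far less forgiving than the earlier step suggested: diethylcarbamoyl brings a 30-fold higher number from compound 2 to compound 3 (1.47 log units; beyond the scatter) and, measured against azidomethyl, a 6.6-fold higher number from compound 1 to compound 3 (0.82 log units; beyond the scatter) and so compound 3 is the weakest of the three. Unlike the other two groups, diethylcarbamoyl joins the ring directly through its carbonyl, with no saturated chain carbon, so this change alters the link as well as the end of the group. An amine on that chain carbon, such as diethylaminomethyl, would help separate these two changes. Nothing shown here gives a reason for the loss.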